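The source may report more compounds than this note shows. Statements on the series, on what has been measured and on what is new or still open speak of the compounds shown alone.

In a functional assay on MGC-803 cells (Homo sapiens) for inhibition, read by MTT assay, with a stated time of 72 h (a higher number here means a weaker inhibitor, a lower number a stronger inhibitor), two compounds have been measured so far:

- compound 1 `Cc1cc(Nc2cc(-c3ccccc3)[nH]n2)n2nc(SCc3ccc(Br)cc3)nc2n1`: 1110 nM
- compound 2 `Cc1cc(Nc2cc(-c3ccccc3)[nH]n2)n2nc(SCc3cccc4ccccc34)nc2n1`: 3120 nM

Compound 2 has the higher of the two numbers, which makes it the weaker inhibitor of the pair. The measured step is a 2.8-fold higher number from compound 1 to compound 2 (0.45 log units; beyond the scatter), a modest change that lies beyond the scatter.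

The next compound, compound 3 `CCCSc1nc2nc(C)cc(Nc3cc(-c4ccccc4)[nH]n3)n2n1`, keeps the shared core but changes the group on sulfur: ethyl in place of naphthalen-1-yl on a saturated chain carbon bound to a sulfur. This places ethyl in place of naphthalen-1-yl on a saturated chain carbon bound to a sulfur; cut one bond further out, it reads (naphthalen-1-yl)methyl to propyl.

Going by the values given here, only one measured step bears on this change, and it is an imperfect guide. That step, a 2.8-fold higher number from compound 1 to compound 2 (0.45 log units; beyond the scatter), exchanged 4-bromophenyl for naphthalen-1-yl, so one ring-bearing group replaced another. Among the compounds with values here, no compound lacking a ring at this place has yet been measured, so the data fix no direction. A shift of similar size either way would not be surprising, but no step beyond the scatter is expected as the central case. The expected change is a 1.0-fold lower number from compound 2 to compound 3 (0.02 log units; within the scatter). For compound 3 the estimated value is 3000 nM, with an expected range of 1000 nM to 10000 nM.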

Compound 3, half-maximal inhibitory concentration: 12600 nM
Compound 3: middle estimate off by 4.2-fold (0.62 log units), on the low side; measured number above the stated range.
By their numbers in this assay, from the lowest: compound 1; then compound 2; then compound 3.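

In this assay, going by these compounds alone, compound 3 is the first compound with no ring in the group on a saturated chain carbon bound to a sulfur, and it is the weakest inhibitor of the three: the change to ethyl gives a 4.0-fold higher number from compound 2 to compound 3 (0.61 log units; beyond the scatter) and an 11-fold higher number from compound 1 to compound 3 (1.06 log units; beyond the scatter). The earlier pair showed only an exchange of one ring-bearing group for another, a 2.8-fold higher number from compound 1 to compound 2 (0.45 log units; beyond the scatter), whereas these steps show that both 4-bromophenyl and naphthalen-1-yl give lower numbers than ethyl, so this place clearly responds to the group it carries. Nothing available explains why the number rises with this change.

The three compounds cannot separate the loss of the ring from the shortening of the group, since ethyl differs from naphthalen-1-yl and 4-bromophenyl in both respects. Plain phenyl would show whether a single ring without bromine keeps the lower numbers, while a longer chain such as hexyl, or a chain ending in an amine or a carboxylic acid, would test how much a group without a ring can recover.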